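A few compounds are considered here, and "the series" means these few. Any claim that something is new, unique, unknown or untested is made for them only; others in the source may bear on it.

Measured in an ADME assay on MT4 cells (Homo sapiens) for cytotoxicity, read by MTT assay, with a stated time of 5 days; a higher number here means that more compound is tolerated, a lower number that less compound is tolerated:

- Compound 1 `C=CCNc1cc(Oc2c(C)cc(/C=C/C#N)cc2C)nc(Nc2ccc(C#N)cc2)n1`: 3050 nM
- Compound 2 `Cc1cc(/C=C/C#N)cc(C)c1Oc1cc(NCCN(C)C)nc(Nc2ccc(C#N)cc2)c1`: 4270 nM
- Compound 3 `Cc1cc(/C=C/C#N)cc(C)c1Oc1cc(Cl)nc(Nc2ccc(C#N)cc2)n1`: 4310 nM

Compound 3, at 4310 nM, stands within the scatter of both compound 1 and compound 2, so these numbers set no order among the three. Compound 4 `COC(Nc1cc(Oc2c(C)cc(/C=C/C#N)cc2C)nc(Nc2ccc(C#N)cc2)n1)OC` differs from compound 3 by one change: a group of 6 heavy atoms (3 carbon, 1 nitrogen, 2 oxygen; no ring) in place of one chlorine atom, on an aromatic carbon. For the measured compounds named here, only one measured step bears on this aromatic carbon, with chloro in place of allylamino. Because of a 1.4-fold higher number from compound 1 to compound 3 (0.15 log units; within the scatter) no change beyond the scatter is expected in this assay when a chain replaces chloro again. The expected result is a 1.2-fold lower number from compound 3 to compound 4 (0.09 log units; within the scatter). For compound 4 the estimated value is 3500 nM, with an expected range of 1500 nM to 8000 nM.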

Compound 4, half-maximal cytotoxic concentration: 3470 nM
Compound 4: the middle estimate sits 1.0-fold (0.00 log units) above what was measured, within the range that was stated.
By their numbers in this assay, from the lowest: compounds 1, 4, 2 and 3 (each within the scatter of the next).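

In this assay the group carrying dimethoxymethyl on the nitrogen, entering in place of chloro, gives a 1.2-fold lower number from compound 3 to compound 4 (0.09 log units; within the scatter) and dimethoxymethyl in place of allyl on that nitrogen gives a 1.1-fold higher number from compound 1 to compound 4 (0.06 log units; within the scatter) as its result. This aromatic carbon therefore now has three groups, chloro and the two substituted amino chains, whose numbers all lie within the scatter of one another, and a chain bearing two oxygen atoms reads no differently here from allylamino.

On these data alone, whether a carboxylic acid, a morpholine ring or a much longer chain at this aromatic carbon would also stay within the scatter remains open. Nothing at hand offers an explanation for these results.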